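Quinoline urea series: solubility notes toward compound 3

The compounds below may be only part of what the source reports. "The series", "measured", "known", "first", "only" and "open" are said of these compounds alone.

The shared core is seen in compound 1 `Cc1cc(NC(=O)Nc2ncccc2C)c2ccccc2n1` and compound 2 `Cc1cc(NC(=O)Nc2cccc(Cl)c2)c2ccccc2n1`. In a physicochemical assay for solubility, at pH 7.4 (on this read-out higher numbers stand for higher solubility and lower numbers for lower solubility), compound 1 gives 1300 nM, and in this assay compound 2 gives 800 nM. Among the measured compounds shown here, the one measured step, a 1.6-fold lower number from compound 1 to compound 2 (0.21 log units; within the scatter), is within the scatter, so the two numbers cannot be ordered; compound 2 simply has the lower of the two numbers, with compound 1 nearest.

Compound 3 `Cc1cc(NC(=O)Nc2cccc(C(N)=O)c2)c2ccccc2n1` is not yet measured. It differs from compound 2 as follows: carbamoyl in place of chloro on an aromatic carbon. For the measured compounds named here, no measured step covers a carbamoyl entering for a chloro on the aromatic ring, and the step from compound 1 to compound 2 concerns a different change, so it gives no direct guide. The expectation rests on the counted difference alone and is a step of a 3.1-fold higher number from compound 2 to compound 3 (0.49 log units; beyond the scatter), expected to land above the scatter but with wide uncertainty. Compound 3 is estimated at 2500 nM, within a range of 800 nM to 8000 nM.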

Compound 3, solubility: 100 nM
The estimate for compound 3 lay 25-fold (1.40 log units) above the measured number; measured number outside the range, below it.
By their numbers in this assay, from the lowest: compound 3; then compounds 2 and 1 (each within the scatter of the next).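

On the aromatic carbon meta to a large group, carbamoyl in place of chloro gives an 8.0-fold lower number from compound 2 to compound 3 (0.90 log units; beyond the scatter) in this assay. Among the compounds shown here, this is the first step that lies beyond the scatter, so the read-out does respond to what sits at this position, which the earlier step could not show. The direction also matters: the entering carbamoyl brings a hydrogen-bond donor and acceptor where chloro has none, yet the number falls, and nothing at hand bears on why.

As far as these compounds go, it remains open whether this fall belongs to carbamoyl specifically or would also follow from other groups at this carbon, such as an amine, a carboxylic acid or a nitrile. Also open, from the compounds shown here alone, is whether carbamoyl would give a step of the same direction and size at another place on this ring.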